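The source may hold more compounds than are shown below. What is called first, only, known or untested is meant among the compounds shown, and "the series" means these compounds.

Compounds with results in a functional assay on CWR22R cells (Homo sapiens) for antiproliferative activity, read by CCK-8 assay, with a stated time of 6 days; on this read-out lower numbers stand for stronger inhibition and higher numbers for weaker inhibition:
compound 1, `N#Cc1ccc(N2CCc3cc(-c4cnc5ccccc5c4)ccc32)cc1C(F)(F)F` — "not determined" (no result reported)
compound 2, `CCN(c1ccc(C#N)c(Cl)c1)c1cc(-c2cncnc2)ccc1C` — > 30000 nM

Compound 1 carries no number, so it sets no point of reference. For compound 2 the entry > 30000 nM is a limit of the assay and not a measured number; compound 2 sits at that limit (the limit of > 30000 nM in this assay, at which 1 of the 2 values shown sits). Among the compounds with values here, with one entry a limit and the other undetermined, no step between measured compounds can be read off, and nothing shows how the read-out answers any change.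

Compound 3, `CCN(c1ccc(C#N)c(Cl)c1)c1cc(-c2cccnc2)ccc1C`, differs from compound 2 in one place: pyridin-3-yl in place of pyrimidin-5-yl on an aromatic carbon. The change is small in size and keeps the ring aromatic and six-membered, so the step from compound 2 to compound 3 is expected to stay within the scatter, with no clear direction; the expected step is an at least 1.2-fold lower number from compound 2 to compound 3 (0.07 log units; that floor lies within the scatter). Compound 3 is therefore estimated at 25000 nM, with a range from 6000 nM to 80000 nM, and a substantial chance that the assay again reports only a limit.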

Compound 3, half-maximal inhibitory concentration: 2000 nM
Compound 3: middle estimate off by 13-fold (1.10 log units), on the high side; the measured number lies below the stated range.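

In this assay the series now has its first readable step, and it shows that this position, on an aromatic carbon para to a methyl group, is not silent: pyridin-3-yl in place of pyrimidin-5-yl gives an at least 15-fold lower number from compound 2 to compound 3 (1.17 log units; beyond the scatter) in the read-out. The change is a single ring atom, with the heavy-atom count unchanged and one hetero atom and one hydrogen-bond acceptor fewer in the entering ring, so a small exchange at this place can move the number well beyond the scatter. The value of compound 2 is a limit of the assay and not a number, so the step has a floor and no upper end: the limit of > 30000 nM in this assay, at which 1 of the 3 values shown sits.

The compounds shown leave open whether the response follows the number of ring nitrogens or where they sit. They also leave open how a plain phenyl ring, or a pyridin-3-yl carrying an amine or a carboxylic acid, would read at this position.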